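Swapping the Urea's Phenyl for an Ester-Bearing Chain

The source may hold more compounds than are shown below. What is called first, only, known or untested is meant among the compounds shown, and "the series" means these compounds.

Of the compounds shown here, two sharing a common core have been measured in a functional assay on HEK293 cells for agonist activity at Vasopressin V2 receptor (Homo sapiens), read by a luciferase reporter and cAMP accumulation; a lower number here means that less compound is needed, a higher number that more compound is needed for the effect. Compound 1 `O=C(NCc1ccc(C(=O)N2CCCCc3ccccc32)c(Cl)c1)Nc1c(F)cccc1F` gives 40 nM in this assay. Compound 2 `Cc1cc(C(=O)N2CCCCc3ccccc32)ccc1CNC(=O)Nc1ccccc1` gives 130 nM in this assay, the higher of the two numbers; compound 1 sits a good deal lower, and that gap exceeds the usual scatter of this kind of measurement.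

The next compound keeps the core of compound 2 and alters only the far end of the urea. Compound 3 `Cc1cc(C(=O)N2CCCCc3ccccc32)ccc1CNC(=O)NCC(=O)OC(C)(C)C` carries (tert-butoxycarbonyl)methyl in place of phenyl on an amide-type nitrogen, so the aromatic ring that ended the chain in compound 2 gives way to a branched, oxygen-bearing chain with no ring at all.

Among the compounds with values here, no measured pair in this small set makes exactly this kind of exchange, so there is no directly comparable step to lean on. Since both measured compounds end the urea with an aromatic ring, the expectation is that removing it costs potency, and compound 3 is estimated at 400 nM, with a plausible range from 100 nM to 2000 nM, meaning an expected shift of a 3.1-fold higher number from compound 2 to compound 3 (0.49 log units; beyond the scatter).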

Compound 3, half-maximal effective concentration: 120 nM
Beside the measured number, compound 3's estimate is 3.3-fold (0.52 log units) above it, within the range that was stated.
By their numbers in this assay, from the lowest: compound 1; then compounds 3 and 2 (each within the scatter of the next).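

In this assay, the exchange of phenyl for (tert-butoxycarbonyl)methyl on the amide-type nitrogen gives a 1.1-fold lower number from compound 2 to compound 3 (0.03 log units; within the scatter), so this large change in the end of the urea leaves the number essentially where it was. Until now, both measured compounds ended the urea in an aromatic ring, which left open whether a ring there was necessary; this pair shows that, on the core of compound 2, a chain with no ring at all can take the place of phenyl and still give a number within the scatter of the original. Nothing available here explains why the two groups perform alike in this read-out.

One pair cannot say which part of the new group matters, and a carboxylic acid in place of the tert-butyl ester, or a plain ethyl group on the same nitrogen, would test whether the ester itself contributes anything. Compound 1 differs from compound 3 in more than one place, so the part of its lower number that comes from the 2,6-difluorophenyl end of its urea, rather than from its chlorine, also remains unsettled.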